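Phenyl for Methyl on the Shared Core

The source may hold more compounds than are shown below. What is called first, only, known or untested is meant among the compounds shown, and "the series" means these compounds.

Compound 1 `Cc1nn(C)c2c1C(c1ccccc1)C(C#N)=C(N)O2` gives 9100 nM in a functional assay on NCI-H2122 cells (Homo sapiens) for inhibition, read by microscopy, with a stated time of 10 days; on this read-out lower numbers stand for stronger inhibition and higher numbers for weaker inhibition. Compound 2 `Cc1nn(C)c2c1C(c1ccc3c(c1)OCCO3)C(C#N)=C(N)O2` gives 8600 nM in this assay, the lower of the two numbers, though so close to compound 1 that the gap lies within the usual scatter. Compound 3 `Cn1nc(-c2ccccc2)c2c1OC(N)=C(C#N)C2c1ccc2c(c1)OCCO2` has not yet been measured; it differs from compound 2 by phenyl in place of methyl on an aromatic carbon. Among the compounds with values here, no measured pair shows this change, so in this assay a step of modest size is expected, if any, with no firm direction. Compound 3 is therefore expected to give 6000 nM, between 1500 nM and 25000 nM, an estimated step of a 1.4-fold lower number from compound 2 to compound 3 (0.16 log units; within the scatter).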

Compound 3, half-maximal inhibitory concentration: 8400 nM
For compound 3 the middle estimate is 1.4-fold (0.15 log units) below the measured one; the range from low to high includes it.
By their numbers in this assay, from the lowest: compounds 3, 2 and 1 (each within the scatter of the next).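

In this assay, within the data shown here, the exchange of methyl for phenyl on this aromatic carbon gives a 1.0-fold lower number from compound 2 to compound 3 (0.01 log units; within the scatter), the first direct reading of any change at this position. The position therefore accommodates phenyl, with its six-membered aromatic ring of carbon only, without a step beyond the scatter. No measurement here speaks to the reason for this result.

The compounds shown leave open whether an amine or a carboxylic acid on this aromatic carbon would also stay within the scatter of compound 2. They also leave open whether this outcome would hold on a core carrying a different group in place of the shared ring substituent of compound 2.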